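The compounds below may be only part of what the source reports. "The series", "measured", "known", "first", "only" and "open" are said of these compounds alone.

Measured so far:
- compound 1 `CCCCCCCCCO[C@@H]1[C@@H](N)[C@@H](OCC(O)CNCCCO)O[C@H](CN)[C@H]1OCCCCCCCCC`: 13.7%
- compound 2 `NC[C@H]1O[C@H](O[C@H]2[C@H](O)[C@@H](O)[C@H](N)C[C@@H]2N)[C@H](N)[C@@H](OCCCc2ccc3ccccc3c2)[C@@H]1OCCCc1ccc2ccccc2c1`: 66.9%
- compound 3 `NC[C@H]1O[C@H](O[C@H]2[C@H](O)[C@@H](OCc3ccc4ccccc4c3)[C@H](N)C[C@@H]2N)[C@H](N)[C@@H](OCc2ccc3ccccc3c2)[C@@H]1O`: 75.9%

In a toxicity assay on the whole organism (J774 cells) for cytotoxicity, with Mus musculus as the target, read by MTT assay, with a stated time of 24 h, tested at 30 uM (a higher number here means a weaker effect of the compound at the concentration tested, a lower number a stronger effect), compound 1 gives the lowest of the three numbers, and both gaps to the others lie beyond the scatter: compound 2 gives 66.9%, and compound 3 gives 75.9%, the larger of the two gaps. Compound 1 is thus the one with the strongest effect among these three at the tested concentration.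

Compound 4 `C=CCO[C@H]1O[C@H](CN)[C@@H](OCCCCCCCCC)[C@H](OCCCCCCCCC)[C@H]1N` has not yet been measured in this assay. Relative to compound 1 the change is vinyl in place of 1-hydroxy-2-((3-hydroxypropyl)amino)ethyl on a saturated chain carbon bound to an oxygen on a saturated carbon. The two nonyl ethers of compound 1 are kept; what goes is a chain carrying three hydrogen-bond donors and three acceptors, and what comes in carries none. Among the measured compounds shown here, no measured pair in this set isolates such a change, so the direction is open. The expected step of a number 13.3 percentage points higher from compound 1 to compound 4 (beyond the scatter) is modest and upward, at most a little beyond the scatter. Compound 4 is therefore expected near 27%, within 6% to 60%.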

Compound 4, a percentage reported as activity, at one concentration (the size of the read-out at that concentration, not a potency): 6.6%
Compound 4: middle estimate off by 20.4 percentage points, on the high side; low and high end bracket the measured number.
By their numbers in this assay, from the lowest: compounds 4 and 1 (each within the scatter of the next); then compounds 2 and 3 (each within the scatter of the next).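

In this assay, vinyl in place of 1-hydroxy-2-((3-hydroxypropyl)amino)ethyl on a saturated chain carbon bound to an oxygen on a saturated carbon gives a number 7.1 percentage points lower from compound 1 to compound 4 (within the scatter). Among the compounds shown here, with the two nonyl ethers kept, the number at this position thus stays low without any of the hydrogen-bond donors and acceptors of the departing chain, which the earlier compounds could not show. No supporting measurement explains this outcome.

The compounds shown leave open how an aminoethyl or carboxylic acid group would read at this position, in place of vinyl. For the compounds shown here, they also leave open what the nonyl ethers themselves contribute, as no pair here tests a shorter chain, such as butyl, in their place.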